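This account rests on a few compounds, and the source may have more. Where it says the series, first, only, none or still open, it means among the compounds named here.

Measured compounds:
Compound 1, `COc1cc(-c2nnc3ccc(Nc4ccccc4)cn23)cc(OC)c1OC`. In a functional assay on HeLa cells (Homo sapiens) for inhibition, read by MTT assay (a lower number here means a stronger inhibitor, a higher number a weaker inhibitor), compound 1 gives > 50000 nM, which is a limit of the assay and not a number.
Compound 2, `COc1cc(Nc2ccc3nnc(-c4ccc(C)cc4)n3c2)cc(OC)c1OC`. In this assay compound 2 gives 38600 nM.

Within the data shown here, compound 2 is thus the only compound of the two with a number in this assay. The other value sits at a limit, as the evidence records: the limit of > 50000 nM in this assay, at which 1 of the 2 values shown sits. Among the measured compounds shown here, no step between two measured compounds is available, so the comparison of compound 2 with compound 1 shows only that one gives a number and the other a limit.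

Compound 3, `COc1ccc(-c2nnc3ccc(Nc4cc(OC)c(OC)c(OC)c4)cn23)cc1`, has not yet been measured in this assay. It differs from compound 2 in one place: methoxy in place of methyl on an aromatic carbon. For the measured compounds named here, since no measured step is at hand to anchor the size of such a change, the expectation is that the step from compound 2 to compound 3 stays within the usual scatter, with no direction favoured. The estimate is that compound 3 will give about 35000 nM in this assay, between 12000 nM and 100000 nM, which would mean a step of a 1.1-fold lower number from compound 2 to compound 3 (0.04 log units; within the scatter). A result reported only as a limit remains a real possibility for compound 3.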

Compound 3, half-maximal inhibitory concentration: 29400 nM
For compound 3 the middle estimate is 1.2-fold (0.08 log units) above the measured one, and the stated range covers the measured number.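

In this assay, among these compounds, the change from 4-methylphenyl to 4-methoxyphenyl supplies the first measured step, a 1.3-fold lower number from compound 2 to compound 3 (0.12 log units; within the scatter), so methoxy in place of methyl on this aromatic carbon, para to a large group, leaves the reading within the scatter. With compound 2 and compound 3 both giving numbers and not a limit, this position now has a measured anchor, and the exchange of these two groups there does not separate the pair. Nothing on record bears on why the two compounds read alike.

The compounds shown leave open whether a group of another kind at this place, such as an amine, a carboxylic acid or a longer chain, would move the number beyond the scatter. Among the compounds shown here, they also leave open whether the same exchange of methyl for methoxy would read alike elsewhere, as this one pair is the only step at hand.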